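The compounds below may be only part of what the source reports. "The series", "measured", "known", "first", "only" and "open" are said of these compounds alone.

Going by the values given here, in a functional assay on SK-OV-3 cells (Homo sapiens) for antiproliferative activity, read by MTT assay, with a stated time of 72 h (a higher number here means a weaker inhibitor, a lower number a stronger inhibitor), compound 1 `C#Cc1cccc(NC(=O)CCc2cccc3c2B(O)OC3)c1` gives 980 nM and compound 2 `O=C(CCc1cccc2c1B(O)OC2)Nc1cccc(-c2cccc(F)c2)c1` gives 480 nM, the lower of the two numbers so far. Next in line is compound 3 `COc1ccc(-c2cccc(NC(=O)CCc3cccc4c3B(O)OC4)c2)cc1`, which differs from compound 2 as follows: 4-methoxyphenyl in place of 3-fluorophenyl on an aromatic carbon. In words, this is 4-methoxyphenyl in place of 3-fluorophenyl on an aromatic carbon, meta to a large group. Among the compounds with values here, only one measured step bears on this change: a 2.0-fold lower number from compound 1 to compound 2 (0.31 log units; beyond the scatter), a modest move that came with 3-fluorophenyl replacing ethynyl. That step swapped ethynyl for a ring-bearing group, whereas the new change swaps one substituted phenyl for another, so it offers only loose guidance. Within the data shown here, no measured pair compares two such phenyl groups, and the data give no direction for the change. Compound 2 at 480 nM therefore serves as the anchor, and no shift beyond the scatter is expected. The expected step is a 1.1-fold higher number from compound 2 to compound 3 (0.03 log units; within the scatter), with wide uncertainty on either side. For compound 3 the estimated value is 520 nM, with an expected range of 220 nM to 1200 nM.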

Compound 3, half-maximal inhibitory concentration: 48 nM
The estimate for compound 3 lay 11-fold (1.03 log units) above the measured number; the measured number lies below the stated range.
By their numbers in this assay, from the lowest: compound 3; then compound 2; then compound 1.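

In this assay, going by these compounds alone, the choice of substituted phenyl on this aromatic carbon, meta to a large group, matters far more than the earlier compounds could show: 4-methoxyphenyl in place of 3-fluorophenyl gives a 10-fold lower number from compound 2 to compound 3 (1.00 log units; beyond the scatter), a larger move than a 2.0-fold lower number from compound 1 to compound 2 (0.31 log units; beyond the scatter) seen on replacing ethynyl with 3-fluorophenyl. Replacing ethynyl with 4-methoxyphenyl gives a 20-fold lower number from compound 1 to compound 3 (1.31 log units; beyond the scatter), so a phenyl ring at this place does not by itself set the size of the step, and the groups on that ring also count. The entering group has one hydrogen-bond acceptor and the leaving group none, but no measurement on hand links the step to that count or to any other feature of the two groups.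

The step changes both the substituent and its numbered place on the phenyl ring, and the compounds shown do not separate these two changes. Also open, as far as these compounds go, is how an unsubstituted phenyl, or a hydroxyl or an amine in place of the methoxy group, would compare with compound 3 at 48 nM.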